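The source may hold more compounds than are shown below. What is called first, only, known or untested is meant among the compounds shown, and "the series" means these compounds.

Measured so far:
- compound 1, `O=C1N/C(=N/c2csc(-c3ccc(Cl)cc3)c2)S/C1=C\c1ccccc1`: > 50000 nM in a functional assay on SW-620 cells (Homo sapiens) for cytotoxicity, read by MTT assay, with a stated time of 72 h; a higher number here means a weaker inhibitor, a lower number a stronger inhibitor
- compound 2, `COc1ccc(/C=C2\S/C(=N\c3csc(-c4ccc(Cl)cc4)c3)NC2=O)cc1`: 28100 nM in this assay

From the compounds shown here alone, compound 1 stands at a limit, not at a number: its result in this assay is the limit (the limit of > 50000 nM in this assay, at which 1 of the 2 values shown sits), so its true potency is unknown beyond that boundary. Compound 3, `O=C1N/C(=N/c2csc(-c3ccc(Cl)cc3)c2)S/C1=C\c1ccc(F)cc1`, differs from compound 1 by one change on the shared core: fluoro in place of hydrogen on an aromatic carbon.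

For the measured compounds named here, only one measured step bears on this. Placing a methoxy at the same ring position gives an at least 1.7-fold lower number from compound 1 to compound 2 (0.25 log units; that floor lies within the scatter), a step whose floor lies within the scatter of repeated measurements. A fluoro at that position is a smaller group than methoxy, and with only a limit to start from, no clear direction can be read. The expected step, an at least 1.1-fold lower number from compound 1 to compound 3 (0.04 log units; that floor lies within the scatter), is therefore none beyond the scatter, with a fair chance that compound 3 also stops at a limit.

Compound 3 is estimated at 45000 nM in this assay, with a range from 20000 nM to 100000 nM.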

Compound 3, half-maximal inhibitory concentration: 8700 nM
Estimate against measurement, compound 3: 5.2-fold (0.71 log units) above; the measured number lies below the stated range.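

In this assay, the change from phenyl to 4-fluorophenyl gives an at least 5.7-fold lower number from compound 1 to compound 3 (0.75 log units; beyond the scatter), so this position now shows a step that clears the scatter, which the methoxy step could not show. For the compounds shown here, compounds 2 and 3 also allow the first comparison at this position with a measured number at both ends: fluoro in place of methoxy gives a 3.2-fold lower number from compound 2 to compound 3 (0.51 log units; beyond the scatter), so which group sits here matters, not only whether hydrogen has been replaced. Compound 1 remains at a limit, so the step from hydrogen to fluoro is a floor and its true size is unknown: the limit of > 50000 nM in this assay, at which 1 of the 3 values shown sits.

Only hydrogen, methoxy and fluoro are shown on this aromatic carbon, so it remains open whether chloro, a nitrile, an amine or a carboxylic acid in the same place would lower the number further or raise it again. From the compounds shown here alone, it also remains open whether the gain belongs to fluoro in general or would carry over to other cell lines, since all of these values come from a single cytotoxicity read-out on one cell line.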